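The compounds below may be only part of what the source reports. "The series", "measured", "known", "first", "only" and "open" are said of these compounds alone.

Compound 1, `Cc1ccccc1-c1nn(Cc2ccc(F)cc2)cc1CNCCN1CCN(C)CC1`, in an ADME assay on Huh-7 cells (Homo sapiens) for cytotoxicity (on this read-out higher numbers stand for lower toxicity in this test and lower numbers for higher toxicity in this test), gives > 20000 nM, which is a limit of the test and not a number.
Compound 2, `Cc1ccccc1-c1nn(-c2ccc(C(F)(F)F)cc2)cc1CNCCN1CCN(C)CC1`, gives 11000 nM in this assay.
Compound 3, `CSc1ccc(-n2cc(CNCCN3CCN(C)CC3)c(-c3ccccc3C)n2)cc1`, gives 17000 nM in this assay.

On the numbers shown, compound 3 sits alongside compound 2: the step of a 1.5-fold higher number from compound 2 to compound 3 (0.19 log units; within the scatter) is small, and the remaining value belongs to compound 1 and is only a limit (the limit of > 20000 nM in this assay, at which 1 of the 3 values shown sits). Compound 4, `Cc1ccccc1-c1nn(-c2ccc(N)cc2)cc1CNCCN1CCN(C)CC1`, has not yet been tested in this assay. It differs from compound 3 in one place: amino in place of methylsulfanyl on an aromatic carbon. For the measured compounds named here, no measured step swaps exactly these two groups. The closest guide is the step from compound 2 to compound 3, which exchanged one substituent on the same ring a 1.5-fold higher number from compound 2 to compound 3 (0.19 log units; within the scatter) and stayed within the scatter, while the step of an at least 1.1-fold lower number from compound 1 to compound 3 (0.07 log units; that floor lies within the scatter) starts from a limit and so sets only a floor. On this basis the step of no change at the digits printed from compound 3 to compound 4 (within the scatter) is expected to stay within the scatter, in no firm direction. Compound 4 is therefore estimated at 17000 nM, with a range from 8000 nM to 40000 nM.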

Compound 4, half-maximal cytotoxic concentration: > 20000 nM
Compound 4 ended at the assay's limit (the forecaster's own chance of this, stated with the estimate: 35%); middle value at least 1.1-fold (0.07 log units) from the limit.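

Amino can stand on this aromatic carbon, para to a large group, without any sign of a lower number in this assay: the change reads an at least 1.1-fold higher number from compound 3 to compound 4 (0.07 log units; that floor lies within the scatter), and against trifluoromethyl it reads an at least 1.8-fold higher number from compound 2 to compound 4 (0.25 log units; that floor lies within the scatter). Both are only floors, so neither shows a real rise. This is also the first group at this place with a hydrogen-bond donor, where methylsulfanyl had none, and the step between compound 1 and compound 4 cannot be read, with both compounds now at the top of the test: the limit of > 20000 nM in this assay, at which 2 of the 4 values shown sit.

As far as these compounds go, how far compound 4 really lies past that limit stays unknown, so it is open whether amino and methylsulfanyl differ here at all. Also open, from the compounds shown here alone, is how a carboxylic acid, a nitrile or a longer chain such as aminomethyl would read on this carbon.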